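The compounds below may be only part of what the source reports. "The series", "measured", "known", "first", "only" and "open" are said of these compounds alone.

compound 1 `C=C(c1ccc(Cl)c(Cl)c1)C1COC2(CCCCC2)OO1` gives 12800 nM
compound 2 `C=C(c1ccc(Cl)c(Cl)c1)C1COC(C)(C)OO1` gives > 100000 nM (a limit, not a number)
compound 3 `C=C(c1ccc(Cl)c(Cl)c1)C1COC2(CCCC2)OO1` gives 4680 nM

In a functional assay on A549 cells (Homo sapiens) for inhibition, read by MTT assay, with a stated time of 72 h (on this read-out higher numbers stand for weaker inhibition and lower numbers for stronger inhibition), compound 1 gives 12800 nM, the higher of the two actual numbers. Compound 3 comes in lower at 4680 nM, a gap that lies beyond the scatter of repeat measurements. Compound 2 reads > 100000 nM, which is a limit of the assay and not a number. So compound 1 is not the best of this small set, but it does give a real number to build on.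

Compound 4 `C=C(c1ccc(Cl)c(Cl)c1Cl)C1COC2(CCCCC2)OO1` keeps the core of compound 1 and makes one change: chloro in place of hydrogen on an aromatic carbon, ortho to a chloro group, ortho to a large group and meta to a chloro group (chloro in place of hydrogen on an aromatic carbon). The three measured compounds all carry the same two chloro groups, so none of them shows what a further chloro does. The expectation in this assay is therefore modest: a small move towards stronger inhibition, quite possibly no larger than the scatter. The expected step is a 1.3-fold lower number from compound 1 to compound 4 (0.11 log units; within the scatter). Compound 4 is estimated at 10000 nM, with an expected range from 3500 nM to 30000 nM.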

Compound 4, half-maximal inhibitory concentration: 1370 nM
For compound 4 the middle estimate is 7.3-fold (0.86 log units) above the measured one, and the stated range ends above it.
By their numbers in this assay, from the lowest: compound 4; then compound 3; then compound 1. At a limit, above all of these: compound 2.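

In this assay the one added chloro gives a 9.3-fold lower number from compound 1 to compound 4 (0.97 log units; beyond the scatter) and so shows that this aromatic carbon, ortho to a chloro group, ortho to a large group and meta to a chloro group, is a place where a small change counts. The earlier compounds shown here all carry the same two chloro groups, so they could say nothing about a further chloro on the ring; compound 4 shows that replacing one hydrogen with one heavy atom is enough to move the read-out well beyond the usual scatter. Nothing measured here explains why this step is so large.

Going by these compounds, with only chloro at this position, it remains open whether chloro itself matters or whether other groups would do the same, and a fluoro, methyl or methoxy group on the same carbon would help to separate those readings. Going by these compounds alone, it also remains open whether the same chloro would bring a similar step on the core of compound 3, the only other compound here with an actual number.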